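The source may hold more compounds than are shown below. What is called first, only, known or untested is meant among the compounds shown, and "the series" means these compounds.

Measured in a functional assay on MCF7 cells (Homo sapiens) for cytotoxicity, read by sulforhodamine B assay; a higher number here means a weaker inhibitor of growth, a lower number a stronger inhibitor of growth:
compound 1 `CC1=CC[C@@H]([C@@](C)(O)CCCC(C)(C)NC(=S)N/N=C\c2ccc(C)cc2)CC1`: 7230 nM
compound 2 `CC1=CC[C@@H]([C@@](C)(O)CCCC(C)(C)NC(=S)N/N=C\c2ccccc2[N+](=O)[O-])CC1`: 18600 nM
compound 3 `CC1=CC[C@@H]([C@@](C)(O)CCCC(C)(C)NC(=S)N/N=C\c2ccc([N+](=O)[O-])cc2)CC1`: 17700 nM

Compound 1 has the lowest number of the three. Both other compounds lie beyond the scatter from it, with a 2.6-fold higher number from compound 1 to compound 2 (0.41 log units; beyond the scatter) and a 2.4-fold higher number from compound 1 to compound 3 (0.39 log units; beyond the scatter). The two nitro compounds do not separate, with a 1.1-fold lower number from compound 2 to compound 3 (0.02 log units; within the scatter).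

Next is compound 4 `CC1=CC[C@@H]([C@@](C)(O)CCCC(C)(C)NC(=S)N/N=C(/C)c2ccccc2)CC1`, which has the same atoms as compound 1, joined differently: a group of 9 heavy atoms (8 carbon, 1 nitrogen; one six-membered aromatic ring of carbon only) in place of a group of 9 heavy atoms (8 carbon, 1 nitrogen; one six-membered aromatic ring of carbon only), on an amide-type nitrogen. For the measured compounds named here, no measured step makes this kind of change, so the evidence is indirect. Going by the values given here, the only steps leaving compound 1 are a 2.6-fold higher number from compound 1 to compound 2 (0.41 log units; beyond the scatter) and a 2.4-fold higher number from compound 1 to compound 3 (0.39 log units; beyond the scatter). Both are modest and both go upward, but they replace the aromatic part with nitro-bearing groups, which compound 4 does not carry. Three compounds cannot fix a trend, and compound 1 may simply sit at the low end of the range. A small upward step in this assay is therefore expected, no larger than those two, and a result within the scatter would not surprise. The estimated step is a 1.4-fold higher number from compound 1 to compound 4 (0.14 log units; within the scatter). For compound 4 the expected value is 10000 nM, with an estimated range of 4500 nM to 22000 nM.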

Compound 4, concentration for 50% growth inhibition: 23600 nM
The estimate for compound 4 lay 2.4-fold (0.37 log units) below the measured number; measured number above the stated range.
By their numbers in this assay, from the lowest: compound 1; then compounds 3, 2 and 4 (each within the scatter of the next).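

In this assay, a change that keeps the atoms and every counted feature of the group on the amide-type nitrogen still gives a 3.3-fold higher number from compound 1 to compound 4 (0.51 log units; beyond the scatter), a step beyond the scatter. Until now, every step beyond the scatter had brought in a nitro group, whereas compound 4 carries none, so a nitro group is not needed for a step upward from compound 1 and the way the same atoms are joined at this position is enough to produce one. Nothing available bears on why this rearrangement changes the number, and the size of the step is all that can be stated.

The compounds shown leave open whether the lower number of compound 1 would survive other groups on the aromatic ring, such as methoxy, chlorine or an amine, or whether a carboxylic acid there would change the picture. They also leave open whether a longer chain in place of the methyl group in compound 4 would move the number further in this assay, and whether this order of compounds would hold in any other cell line.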